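A few compounds are considered here, and "the series" means these few. Any claim that something is new, unique, unknown or untested is made for them only; others in the source may bear on it.

In a functional assay on WM-115 cells (Homo sapiens) for cytotoxicity, read by MTT assay, with a stated time of 46 h (a lower number here means a stronger inhibitor, a higher number a weaker inhibitor), compound 1 `O=C1/C(=C\c2ccc(Cl)cc2)C(c2ccccc2)Oc2ccccc21` stands at 27400 nM while compound 2 `N#Cc1ccc(Cc2coc3ccccc3c2=O)cc1` stands at 6300 nM and so holds the lower of the two numbers, by a gap beyond the usual scatter of repeat measurements. The two compounds differ in more than one place, so this gap cannot be pinned on any single group. Compound 3 `O=c1c(Cc2ccc(F)cc2)coc2ccccc12` keeps the core of compound 2 and makes a single change (fluoro in place of cyano on an aromatic carbon) that amounts to fluoro in place of cyano on an aromatic carbon, para to a large group. Going by the values given here, no measured pair here shows what such a swap does, so any expectation remains loose. Compound 2 at 6300 nM is the only close reference for the new compound. In this assay a small step is expected, towards a slightly higher number and no larger than the scatter, and the estimated move a 1.4-fold higher number from compound 2 to compound 3 (0.15 log units; within the scatter) reflects that expectation. For compound 3 an expected value of 9000 nM within a range of 3000 nM to 27000 nM is the estimate.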

Compound 3, half-maximal inhibitory concentration: 53200 nM
Compound 3: the middle estimate sits 5.9-fold (0.77 log units) below what was measured, outside the stated range (above it).
By their numbers in this assay, from the lowest: compound 2; then compounds 1 and 3 (each within the scatter of the next).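

In this assay the swap of fluoro in place of cyano, on an aromatic carbon para to a large group, gives an 8.4-fold higher number from compound 2 to compound 3 (0.93 log units; beyond the scatter) and so shows that the number responds to what sits at this position. Going by these compounds alone, this is the first comparison here between compounds that differ in one place only, so it is the first direct sign that the core alone does not set the number and that, of these two groups, cyano goes with the lower number. Nothing available explains why so small a swap moves the number this far.

Within the data shown here, with only two groups seen at this position, a single step cannot tell whether cyano lowers the number or fluoro raises it, and a plain hydrogen on the same carbon would help separate those two readings. As far as these compounds go, whether other groups at this place, such as a methoxy, an amine or a carboxylic acid, would fall nearer compound 2 or compound 3 remains open, as does whether the same swap would act alike on the core of compound 1.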